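Chloro-to-amino swap on the shared core

This account rests on a few compounds, and the source may have more. Where it says the series, first, only, none or still open, it means among the compounds named here.

Two members of the series carry the same urea-linked scaffold and differ only on the fused six-membered ring of the shared core. Compound 1, `Nc1nn(C(=O)Nc2ccc(Cc3ccccc3)cc2)c2ccccc12`, has no result reported: in a functional assay on NCI/ADR-RES cells (Homo sapiens) for antiproliferative activity, read by sulforhodamine B assay, with a stated time of 48 h (on this read-out higher numbers stand for weaker inhibition of growth and lower numbers for stronger inhibition of growth), compound 1 stands as "not determined" (no result reported). Among the compounds with values here, compound 2, `Nc1nn(C(=O)Nc2ccc(Cc3ccccc3)cc2)c2ccc(Cl)cc12`, is the only member with a number: in this assay compound 2 gives 39100 nM, and with a single value there is nothing to rank it against. Compound 3, `Nc1ccc2c(c1)c(N)nn2C(=O)Nc1ccc(Cc2ccccc2)cc1`, is the new entry. It differs from compound 2 by amino in place of chloro on an aromatic carbon. Within the data shown here, no step between two measured compounds is available for this change, so size and direction can only be expected rather than read from data. The expected step from compound 2 to compound 3 is a 1.3-fold higher number from compound 2 to compound 3 (0.11 log units; within the scatter), a shift in this assay roughly at the edge of the usual scatter and not clearly beyond it. For compound 3 the estimate in this assay is 50000 nM, with a range from 15000 nM to 160000 nM. Because compound 2 gives 39100 nM, the starting point is already weak, and a weak reading for compound 3 is therefore what is expected.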

Compound 3, concentration for total growth inhibition: 75100 nM
Estimate against measurement, compound 3: 1.5-fold (0.18 log units) below; the range from low to high includes it.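

In this assay, within the data shown here, the first readable step on the fused six-membered ring of the shared core, amino in place of chloro on an aromatic carbon, meta to a fused ring and para to a fused ring, gives a 1.9-fold higher number from compound 2 to compound 3 (0.28 log units; within the scatter) and so does not separate the two groups on this read-out. At this position, then, a chloro with no hydrogen-bond donor or acceptor and an amino that carries both read alike, and the series gains no activity from the swap. No measured property of either group accompanies this result, and the step stands without an explanation.

Going by these compounds, with no result for compound 1, the steps from the core without a group at this position to compound 2 and to compound 3 cannot be read, so it stays open whether either group matters at all compared with hydrogen. Also open, on these data alone, is how a methoxy group, a carboxylic acid or an acetamide at this same position would read in this assay when set against these two compounds.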